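The source may hold more compounds than are shown below. What is called first, only, known or untested is meant among the compounds shown, and "the series" means these compounds.

Measured compounds:
compound 1, `COc1cc(/C=C2\C(=O)Nc3ccc(Cl)cc32)ccc1OCCCN1CC(C)OC(C)C1`: 2770 nM
compound 2, `COc1cc(/C=C2\C(=O)Nc3ccc(C)cc32)ccc1OCCCN1CC(C)OC(C)C1`: > 20000 nM
compound 3, `COc1cc(/C=C2\C(=O)Nc3ccc(Cl)cc32)ccc1OCCCN1CCN(c2ncccc2C(F)(F)F)CC1`: 1530 nM

In a functional assay on BT-549 cells (Homo sapiens) for cytotoxicity, read by MTT assay, with a stated time of 48 h (a lower number here means a stronger inhibitor, a higher number a weaker inhibitor), compound 1 gives 2770 nM. Compound 2 reaches only a limit of this assay, > 20000 nM, so no number is known for it; this is the limit of > 20000 nM in this assay, at which 1 of the 3 values shown sits. The change from compound 1 to compound 2 is methyl in place of chloro on an aromatic carbon, and it made an at least 7.2-fold higher number from compound 1 to compound 2 (0.85 log units; beyond the scatter). Compound 3 gives 1530 nM in this assay. The difference between the core of compound 1 and the core of compound 3 is not broken down here.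

Compound 4, `COc1cc(/C=C2\C(=O)Nc3ccc(C)cc32)ccc1OCCCN1CCN(c2ncccc2C(F)(F)F)CC1`, carries the same change against compound 3: methyl in place of chloro on an aromatic carbon, at a place described in the same words. The step from compound 3 to compound 4 is therefore expected to be a 7.8-fold higher number from compound 3 to compound 4 (0.89 log units; beyond the scatter), resting on the earlier step of an at least 7.2-fold higher number from compound 1 to compound 2 (0.85 log units; beyond the scatter). Compound 4 is expected to give about 12000 nM, between 5000 nM and 30000 nM, with a fair chance that only a limit is reported.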

Compound 4, half-maximal inhibitory concentration: > 20000 nM
Compound 4: no number, only a limit; the forecaster's own chance of this, stated with the estimate: 40%; at least 1.6-fold (0.22 log units) between middle value and limit.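

In this assay, methyl in place of chloro on an aromatic carbon gives an at least 13-fold higher number from compound 3 to compound 4 (1.11 log units; beyond the scatter), so the loss seen on the core of compound 1 recurs on the core of compound 3. The two steps point the same way, but their sizes cannot be compared: the same change on two cores in this assay, an at least 7.2-fold higher number (0.85 log units; beyond the scatter) from compound 1 to compound 2 and an at least 13-fold higher number (1.11 log units; beyond the scatter) from compound 3 to compound 4; the limit leaves it open whether they differ Neither methyl compound gives a number, and two cores do not establish a rule for the wider series: the limit of > 20000 nM in this assay, at which 2 of the 4 values shown sit.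

Still open, on these data alone, is how fluoro, bromo or methoxy at this aromatic carbon would compare with chloro and methyl. Also open, as far as these compounds go, is whether the same change carries over with a longer chain or a different amine at the end of the chain.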